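Amide group swaps in the series: compound 3 to compound 4

The source may report more compounds than this note shows. Statements on the series, on what has been measured and on what is new or still open speak of the compounds shown alone.

In an ADME assay on L6 cells (Rattus norvegicus) for cytotoxicity (on this read-out higher numbers stand for weaker inhibition and lower numbers for stronger inhibition), compound 1 (`O=C(Nc1c(O)cccc1-c1nc2c(C(=O)O)cccc2o1)c1ccccc1O`) gives 85100 nM, compound 2 (`O=C(Nc1c(O)cccc1-c1nc2c(C(=O)O)cccc2o1)c1cccnc1`) gives 240000 nM and compound 3 (`O=C(Nc1c(O)cccc1-c1nc2c(C(=O)O)cccc2o1)c1cnccn1`) gives 94400 nM. The position of compound 3 is fixed by two measured steps: a 1.1-fold higher number from compound 1 to compound 3 (0.05 log units; within the scatter) and a 2.5-fold lower number from compound 2 to compound 3 (0.41 log units; beyond the scatter). Compound 4 (`O=C(Nc1c(O)cccc1-c1nc2c(C(=O)O)cccc2o1)c1cc(-c2ccccc2)on1`) carries 5-phenyl-1,2-oxazol-3-yl in place of pyrazin-2-yl on a carbonyl carbon, with 5-phenyl-1,2-oxazol-3-yl in place of pyrazin-2-yl on a carbonyl carbon. The largest measured step at this place, a 2.8-fold higher number from compound 1 to compound 2 (0.45 log units; beyond the scatter), is modest, and no measured swap brings in a group of this kind. A modest step toward a lower number in this assay is therefore expected, with the direction uncertain. The estimated step is a 2.4-fold lower number from compound 3 to compound 4 (0.37 log units; beyond the scatter). Compound 4 is estimated at 40000 nM, with an expected range from 12000 nM to 130000 nM.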

Compound 4, half-maximal inhibitory concentration: 141000 nM
Beside the measured number, compound 4's estimate is 3.5-fold (0.55 log units) below it, and the stated range ends below it.
By their numbers in this assay, from the lowest: compounds 1, 3, 4 and 2 (each within the scatter of the next, the first and the last beyond it).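

In this assay the swap to 5-phenyl-1,2-oxazol-3-yl gives a 1.5-fold higher number from compound 3 to compound 4 (0.17 log units; within the scatter) and a 1.7-fold lower number from compound 2 to compound 4 (0.23 log units; within the scatter) and a 1.7-fold higher number from compound 1 to compound 4 (0.22 log units; within the scatter). The larger group, with its added six-membered aromatic ring of carbon only, therefore stays within the scatter of all three earlier compounds, so this position on the carbonyl carbon accepts more than the single-ring groups shown before. Nothing available explains this result.

Still open, on these data alone, is whether an amine or a carboxylic acid on the carbonyl carbon would stay within this range, and whether a longer chain there would do the same.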